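This account rests on a few compounds, and the source may have more. Where it says the series, first, only, none or still open, it means among the compounds named here.

Compound 2 `CC(C)=CCC[C@]1(C)/C=C/[C@@H](OC(=O)C=C(C)C)[C@](C)(O)/C=C/C(=O)/C(C[Si](C)(C)C(C)(C)C)=C\C1` stands at the higher of the two numbers recorded in a functional assay on A549 cells (Homo sapiens) for antiproliferative activity, read by MTT assay, with a stated time of 48 h (on this read-out lower numbers stand for stronger inhibition and higher numbers for weaker inhibition), in which compound 2 gives 4200 nM. In this assay compound 1 `CC(C)=CCC[C@]1(C)/C=C/[C@@H](OC(=O)C=C(C)C)[C@](C)(O)/C=C/C(=O)/C(CN2CCCC2)=C\C1` gives 180 nM. Compound 3 `CC(C)=CCC[C@]1(C)/C=C/[C@@H](OC(=O)C=C(C)C)[C@](C)(O)/C=C/C(=O)/C(C(=O)N2CCCC2)=C\C1` differs from compound 2 by a group of 7 heavy atoms (5 carbon, 1 nitrogen, 1 oxygen; one five-membered non-aromatic ring with 1 hetero atom) in place of a group of 8 heavy atoms (7 carbon, 1 silicon; no ring), on a double-bonded ring carbon. The only measured step that bears on this change is a 23-fold higher number from compound 1 to compound 2 (1.37 log units; beyond the scatter), a large step; the change to compound 3 runs in the reverse sense, so a large fall in the number is expected, tempered because the entering group differs from that of compound 1 shown by 180 nM. Compound 3 is thus estimated at 500 nM, within 150 nM to 2000 nM, an expected step of an 8.4-fold lower number from compound 2 to compound 3 (0.92 log units; beyond the scatter).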

Compound 3, half-maximal inhibitory concentration: 13000 nM
The estimate for compound 3 lay 26-fold (1.41 log units) below the measured number; measured number outside the range, above it.
By their numbers in this assay, from the lowest: compound 1; then compound 2; then compound 3.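

In this assay, keeping the pyrrolidine ring and changing only (pyrrolidin-1-yl)methyl to (pyrrolidin-1-yl)carbonyl on the double-bonded ring carbon gives a 72-fold higher number from compound 1 to compound 3 (1.86 log units; beyond the scatter), so the ring alone does not secure the lower number at this position. The carbonyl-linked group also stands behind the silicon-bearing group, with a 3.1-fold higher number from compound 2 to compound 3 (0.49 log units; beyond the scatter). Nothing given here explains these steps. The compounds shown leave open whether other amines, such as (piperidin-1-yl)methyl or (morpholin-4-yl)methyl, would match compound 1 at this position, and where a carboxylic acid there would stand.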